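Swapping 3-bromophenyl for 2-methylphenyl on an amide-type nitrogen

The compounds below may be only part of what the source reports. "The series", "measured", "known", "first", "only" and "open" are said of these compounds alone.

In a physicochemical assay, with a stated time of 30 min (on this read-out higher numbers stand for weaker inhibition and lower numbers for stronger inhibition), compound 1 `CCc1ccc(NC(=O)C2Cc3cc(OC)c(OC)cc3C2=O)cc1` gives 76.2 ug/mL and compound 2 `COc1cc2c(cc1OC)C(=O)C(C(=O)Nc1cccc(Cl)c1)C2` gives 76.3 ug/mL while compound 3 `COc1cc2c(cc1OC)C(=O)C(C(=O)Nc1cccc(Br)c1)C2` gives 58.9 ug/mL and so stands level with both, inside the scatter. Compound 4 `COc1cc2c(cc1OC)C(=O)C(C(=O)Nc1ccccc1C)C2` carries 2-methylphenyl in place of 3-bromophenyl on an amide-type nitrogen. Two measured swaps on that nitrogen bear on this: a 1.0-fold higher number from compound 1 to compound 2 (0.00 log units; within the scatter) and a 1.3-fold lower number from compound 1 to compound 3 (0.11 log units; within the scatter) were both within the scatter, as was a 1.3-fold lower number from compound 2 to compound 3 (0.11 log units; within the scatter) on an aromatic carbon. For the measured compounds named here, no measured compound carries 2-methylphenyl, so the expectation remains uncertain. In this assay the expected step, a 1.2-fold higher number from compound 3 to compound 4 (0.06 log units; within the scatter) by estimate, stays within the scatter. Compound 4 is expected to read 68 ug/mL with an estimated range from 40 ug/mL to 115 ug/mL in this test.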

Compound 4, half-maximal inhibitory concentration: 43.7 ug/mL
Beside the measured number, compound 4's estimate is 1.6-fold (0.19 log units) above it; the range from low to high includes it.
By their numbers in this assay, from the lowest: compounds 4, 3, 1 and 2 (each within the scatter of the next).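

In this assay, 2-methylphenyl on the amide-type nitrogen gives no step beyond the scatter against any of the other three groups: the steps are a 1.3-fold lower number from compound 3 to compound 4 (0.13 log units; within the scatter) and a 1.7-fold lower number from compound 2 to compound 4 (0.24 log units; within the scatter) and a 1.7-fold lower number from compound 1 to compound 4 (0.24 log units; within the scatter). With this fourth group, the read-out still stays level across every change made at this place. Nothing measured here offers a reason for this flat picture. On these data alone, whether a phenyl ring carrying an amine or a carboxylic acid, or a longer chain in place of the ring, would move the number beyond the scatter remains open.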